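Working notes: one methoxy removed, compound 3 to compound 4

A few compounds are considered here, and "the series" means these few. Any claim that something is new, unique, unknown or untested is made for them only; others in the source may bear on it.

Measured so far in a functional assay on Huh-7 cells (Homo sapiens) for inhibition, read by sulforhodamine B assay, with a stated time of 72 h; a higher number here means a weaker inhibitor, a lower number a stronger inhibitor:
compound 1, `COc1ccc(C(=O)/C=C/c2cn(-c3ccccc3)nc2-c2cccnc2)cc1OC`, gives 3100 nM
compound 2, `COc1cc(C(=O)/C=C/c2cn(-c3ccccc3)nc2-c2ccncc2)cc(OC)c1OC`, gives 3500 nM
compound 3, `COc1ccc(C(=O)/C=C/c2cn(-c3ccccc3)nc2-c2ccncc2)c(OC)c1OC`, gives 3700 nM

Compound 3 gives the highest number of the three in this assay, but its gap to compound 2 and its gap to compound 1 both lie within the usual scatter of repeated measurements, so no order among the three can be read from these numbers. Going by the values given here, no two measured compounds differ in a single place, so no measured step is known for this series.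

Compound 4, `COc1ccc(C(=O)/C=C/c2cn(-c3ccccc3)nc2-c2ccncc2)cc1OC`, comes from compound 3 by the change (hydrogen in place of methoxy on an aromatic carbon), that is, hydrogen in place of methoxy on an aromatic carbon. Among the compounds with values here, with no measured step to draw on and the three measured numbers sitting close together, the step from compound 3 to compound 4 is expected to be small: a 1.1-fold lower number from compound 3 to compound 4 (0.02 log units; within the scatter), none beyond the scatter in either direction. For compound 4 the estimate in this assay is 3500 nM, with an expected range from 1700 nM to 7000 nM.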

Compound 4, half-maximal inhibitory concentration: 2000 nM
Compound 4: the middle estimate sits 1.8-fold (0.24 log units) above what was measured, within the range that was stated.
By their numbers in this assay, from the lowest: compounds 4, 1, 2 and 3 (each within the scatter of the next).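

Hydrogen in place of methoxy, at the position ortho to a large group, gives the first measured step in this series in this assay (a 1.9-fold lower number from compound 3 to compound 4 (0.27 log units; within the scatter)), and the same kind of change gives a second step (a 1.8-fold lower number from compound 2 to compound 4 (0.24 log units; within the scatter)), while pyridin-4-yl in place of pyridin-3-yl gives a third (a 1.6-fold lower number from compound 1 to compound 4 (0.19 log units; within the scatter)). All three steps lie within the scatter, so neither change, as far as these compounds show, moves the number measurably, and the methoxy at this position is not shown to be needed for the activity seen in this assay. No evidence bears on why these steps are this small.

From the compounds shown here alone, whether a group other than hydrogen or methoxy at this position, such as an amine, a carboxylic acid or a longer alkoxy chain, would give a step beyond the scatter remains open.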